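The source may report more compounds than this note shows. Statements on the series, on what has been measured and on what is new or still open speak of the compounds shown alone.

Working notes on a small set of thiourea-bearing amides. Compound 1 `NC(=O)c1c(NC(=O)c2ccccc2Cl)sc2c1CCN(C(=S)Nc1cc(C(F)(F)F)cc(C(F)(F)F)c1)C2` gives, in a functional assay on HL-60 cells (Homo sapiens) for antiproliferative activity, with a stated time of 24 h (on this read-out lower numbers stand for stronger inhibition and higher numbers for weaker inhibition), 6500 nM. Compound 3 `NC(=O)c1c(NC(=O)c2ccccc2F)sc2c1CCN(C(=S)Nc1cc(C(F)(F)F)cc(C(F)(F)F)c1)C2` differs from compound 1 by fluoro in place of chloro on an aromatic carbon; in this assay compound 3 gives 17900 nM, and the step of a 2.8-fold higher number from compound 1 to compound 3 (0.44 log units; beyond the scatter) goes against this compound. Compound 2 `NC(=O)c1c(NC(=O)c2ccccc2Br)sc2c1CCN(C(=S)Nc1ccccc1Cl)C2` carries a different core: its difference from compound 1 is not broken down here. In this assay compound 2 gives 14600 nM, which against compound 3 falls within the scatter, and against compound 1 is a higher number beyond the scatter.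

Compound 4 `NC(=O)c1c(NC(=O)c2ccccc2Br)sc2c1CCN(C(=S)Nc1ccccc1F)C2` is not yet measured. It differs from compound 2 by fluoro in place of chloro on an aromatic carbon. The change is the same one as between compound 1 and compound 3, at a place described in the same words, on an aromatic carbon of a six-membered aromatic ring of carbon only, ortho to a large group; cut one bond further out, though, it reads (2-chlorophenyl)amino to (2-fluorophenyl)amino here, whereas between compound 1 and compound 3 it reads ((2-chlorophenyl)carbonyl)amino to ((2-fluorophenyl)carbonyl)amino. Going by the values given here, only one measured instance of the step exists, and it sits on the other arm of the molecule, so the expectation is held loosely. From compound 2 to compound 4 a step of a 1.5-fold higher number from compound 2 to compound 4 (0.18 log units; within the scatter) is expected, smaller than the measured one because a 2.8-fold higher number from compound 1 to compound 3 (0.44 log units; beyond the scatter) stands on a different core and a different arm. Compound 4 is expected to give about 22000 nM, estimated to lie between 10000 nM and 50000 nM.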

Compound 4, half-maximal inhibitory concentration: > 50000 nM
Compound 4 gave a limit, no number (the forecaster's own chance of this, stated with the estimate: 15%); middle value at least 2.2-fold (0.35 log units) from the limit.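

In this assay, fluoro in place of chloro on an aromatic carbon goes the same way in both pairs that carry it, with an at least 3.4-fold higher number from compound 2 to compound 4 (0.53 log units; beyond the scatter) set beside a 2.8-fold higher number from compound 1 to compound 3 (0.44 log units; beyond the scatter); both steps lie beyond the scatter and both go against the fluoro compound, so within these two pairs the direction carries from one core to the other, though two pairs make no rule for the series. The data do not show that the size of the step carries over as well: the same change on two cores in this assay, a 2.8-fold higher number (0.44 log units; beyond the scatter) from compound 1 to compound 3 and an at least 3.4-fold higher number (0.53 log units; beyond the scatter) from compound 2 to compound 4; the limit leaves it open whether they differ Compound 4 gives a limit of the assay and not a number, > 50000 nM, so the full size of its step stays unknown, and this is the only such value in the set: the limit of > 50000 nM in this assay, at which 1 of the 4 values shown sits.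

The compounds shown leave open whether the step depends on the core, on the arm that carries the change, or on both, as the two pairs differ in more than one of these. They also leave open how a methoxy group, a nitrile or an amine would read out at the place now held by chloro or fluoro, and whether any such group would bring the numbers down from those seen here.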